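The source may report more compounds than this note shows. Statements on the series, on what has been measured and on what is new or still open speak of the compounds shown alone.

Measured so far in a functional assay on PC-3 cells (Homo sapiens) for antiproliferative activity, read by MTT assay, with a stated time of 48 h; on this read-out lower numbers stand for stronger inhibition and higher numbers for weaker inhibition:
- compound 1 `COc1ccc(CN(C(=O)CSc2nc3ccccc3s2)c2cc(OC)c(OC)c(OC)c2)cc1C`: 34300 nM
- compound 2 `COc1ccc(CN(C(=O)CSc2nc3ccccc3s2)c2cc(OC)c(OC)c(OC)c2)cc1O`: 2110 nM

Compound 2 holds the lower of the two numbers, at 2110 nM. The next compound to read is compound 3 `COc1ccc(CN(C(=O)CSc2nc3ccccc3s2)c2cc(OC)c(OC)c(OC)c2)cc1[N+](=O)[O-]`, which keeps the shared core and alters one group: nitro in place of hydroxy on an aromatic carbon. This is nitro in place of hydroxy on an aromatic carbon, ortho to a methoxy group, so 3-hydroxy-4-methoxybenzyl becomes 4-methoxy-3-nitrobenzyl.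

Going by the values given here, only one measured step bears on this place: a 16-fold lower number from compound 1 to compound 2 (1.21 log units; beyond the scatter), with hydroxy in place of methyl. That step is large and lies beyond the scatter. Among the compounds with values here, no measured compound carries nitro, so its size is only a loose guide. Compound 3 lacks the hydroxy, as does compound 1 at 34300 nM, so a higher number is expected in this assay, though probably not as high as that of compound 1. The expected change is a 4.7-fold higher number from compound 2 to compound 3 (0.68 log units; beyond the scatter), a moderate rise with wide uncertainty. In this assay the estimate for compound 3 is 10000 nM, with an expected range of 2500 nM to 40000 nM.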

Compound 3, half-maximal inhibitory concentration: 26500 nM
For compound 3 the middle estimate is 2.7-fold (0.42 log units) below the measured one, and the stated range covers the measured number.
By their numbers in this assay, from the lowest: compound 2; then compounds 3 and 1 (each within the scatter of the next).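

In this assay, the change from hydroxy to nitro gives a 13-fold higher number from compound 2 to compound 3 (1.10 log units; beyond the scatter), so the low number of compound 2 is lost with a second group as well as with methyl. The two groups without the hydroxy cannot be told apart here, with a 1.3-fold lower number from compound 1 to compound 3 (0.11 log units; within the scatter), even though nitro brings more heavy atoms and hydrogen-bond acceptors than methyl; among these three compounds, only the hydroxy of compound 2 at 2110 nM stands apart at this position, and no compound goes against that reading. No measurement at hand offers a reason for this gap between hydroxy and the other two groups.

Going by these compounds, whether the lower number belongs to hydroxy alone remains open, as an amine, a fluorine or a carboxylic acid on this same aromatic carbon could either share it or lose it. Also open, on these data alone, is whether a hydroxy on another carbon of this ring, or a longer ether chain in place of the neighbouring methoxy group, would keep the number of compound 2.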